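Compound 3: adding a fluoromethylphenyl to a limit-bound compound

This account rests on a few compounds, and the source may have more. Where it says the series, first, only, none or still open, it means among the compounds named here.

In a physicochemical assay for solubility, in phosphate buffer (a higher number here means a more soluble compound, a lower number a less soluble compound), compound 1 `Cc1cc(S(=O)(=O)NCCCC[C@@H](Nc2cc(C)c(F)c(C)c2)C(=O)NO)ccc1F` gives > 5 ug/mL, which is a limit and not a number. From the compounds shown here alone, compound 2 `CO[C@H](C[C@H](CCN(C)CCCc1ccccc1)C(=O)NO)c1ccc(F)cc1` gives > 5 ug/mL, also a limit and not a number, so its position stays open. The measured record amounts to the limit of > 5 ug/mL in this assay, at which 2 of the 2 values shown sit. Compound 3 `CO[C@H](C[C@H](CCN(C)CCCc1ccc(F)c(C)c1)C(=O)NO)c1ccc(F)cc1` carries 4-fluoro-3-methylphenyl in place of phenyl on a saturated chain carbon, three bonds along the chain from an amine nitrogen. Within the data shown here, no measured step exists to size this change in this assay. The expected step, a step that the limit leaves unreadable from compound 2 to compound 3, is estimated to stay within the usual scatter, with no direction favoured. For compound 3 the estimate is 6 ug/mL, with an expected range of 3 ug/mL to 15 ug/mL.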

Compound 3, solubility: > 5 ug/mL
Compound 3 was reported as a limit; the forecaster's own chance of this, stated with the estimate: 65%; the middle value lies beyond the limit too.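

No step from compound 2 to compound 3 can be read in this assay, since both results are limits and not numbers: the limit of > 5 ug/mL in this assay, at which 3 of the 3 values shown sit.

The compounds shown leave open how far each of compounds 1, 2 and 3 lies beyond that limit.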